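The source may report more compounds than this note shows. Statements on the series, on what has been measured and on what is new or still open speak of the compounds shown alone.

Measured in a functional assay on DU-145 cells (Homo sapiens) for antiproliferative activity, read by MTT assay, with a stated time of 72 h; on this read-out higher numbers stand for weaker inhibition and lower numbers for stronger inhibition:
compound 1 `CN(c1ccc(Cl)cc1)S(=O)(=O)C1CC2OC1C(c1ccc(NC(=O)CCCCCCC(=O)O)cc1)=C2c1ccc(O)cc1`: 72100 nM
compound 2 `CN(c1cccc2ccccc12)S(=O)(=O)C1CC2OC1C(c1ccc(NC(=O)CCCCCCC(=O)O)cc1)=C2c1ccc(O)cc1`: 70900 nM
compound 3 `CCN(c1ccccc1)S(=O)(=O)C1CC2OC1C(c1ccc(NC(=O)CCCCCCC(=O)O)cc1)=C2c1ccc(O)cc1`: > 100000 nM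

The entry for compound 3 is a limit of the assay, not a number. Compound 2 stands level with compound 1, as the step shows: a 1.0-fold lower number from compound 1 to compound 2 (0.01 log units; within the scatter). Compound 4 `CCN(c1ccccc1Cl)S(=O)(=O)C1CC2OC1C(c1ccc(NC(=O)CCCCCCC(=O)O)cc1)=C2c1ccc(O)cc1` is still unmeasured. It carries (2-chlorophenyl)(ethyl)amino in place of methyl(naphthalen-1-yl)amino on a sulfonyl sulfur.

The closest evidence comes from the two steps to ethyl(phenyl)amino: an at least 1.4-fold higher number from compound 2 to compound 3 (0.14 log units; that floor lies within the scatter) and an at least 1.3-fold higher number from compound 1 to compound 3 (0.14 log units; that floor lies within the scatter). Both are only floors, and both lie within the scatter. In this assay, therefore, no change beyond the scatter is expected, and the expected step is small: a 1.2-fold higher number from compound 2 to compound 4 (0.08 log units; within the scatter). Compound 4 is estimated at 85000 nM, with an expected range from 50000 nM to 140000 nM.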

Compound 4, half-maximal inhibitory concentration: > 100000 nM
Compound 4: only a limit was reported (the forecaster's own chance of this, stated with the estimate: 40%); middle value at least 1.1-fold (0.07 log units) away from the limit.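

In this assay, the entry for compound 4 is a limit of the assay, not a number, and it puts a second ethyl-bearing amino group on the sulfonyl sulfur at that limit, after compound 3: the limit of > 100000 nM in this assay, at which 2 of the 4 values shown sit. The change gives an at least 1.4-fold higher number from compound 2 to compound 4 (0.14 log units; that floor lies within the scatter) and an at least 1.3-fold higher number from compound 1 to compound 4 (0.14 log units; that floor lies within the scatter), so neither floor shows a firm loss. The step from compound 3 to compound 4, chloro in place of hydrogen on an aromatic carbon, cannot be read, as both entries are limits.

On these data alone, what a propyl chain in place of the ethyl on that amino group would give stays open.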